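Chloro for fluoro in the azide pair

The source may hold more compounds than are shown below. What is called first, only, known or untested is meant among the compounds shown, and "the series" means these compounds.

Values in an ADME assay on L6 cells (Rattus norvegicus) for inhibition, read by resazurin assay, with a stated time of 72 h (a higher number here means a weaker inhibitor, a lower number a stronger inhibitor), so far:
- compound 1 `CS(=O)(=O)C[C@H]1O[C@@H](n2cnc3c(N)nc(Cl)nc32)[C@H](O)[C@@H]1O` gives 156000 nM
- compound 2 `[N-]=[N+]=NC[C@H]1O[C@@H](n2cnc3c(N)nc(F)nc32)[C@H](O)[C@@H]1O` gives 3100 nM

Compound 2 holds the lower of the two numbers, and its gap to compound 1 lies beyond the usual scatter. Among the compounds with values here, only two compounds have been measured, so this position says little about the wider series.

The next compound is compound 3 `[N-]=[N+]=NC[C@H]1O[C@@H](n2cnc3c(N)nc(Cl)nc32)[C@H](O)[C@@H]1O`. It differs from compound 2 at one place chloro in place of fluoro on an aromatic carbon with chloro in place of fluoro on an aromatic carbon, between two ring nitrogen atoms.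

Within the data shown here, no measured pair isolates this exchange. Among the measured compounds shown here, the only measured chloro compound is compound 1 at 156000 nM in this assay, and it also differs from compound 3 elsewhere in the structure. That value therefore gives only a weak hint towards a higher number. A moderate move in that direction is expected, though a result within the scatter of compound 2 would be no surprise. The expected change is a 2.9-fold higher number from compound 2 to compound 3 (0.46 log units; beyond the scatter) in this assay.

For compound 3 the estimated value is 9000 nM with an expected range from 2500 nM to 40000 nM as the likely span.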

Compound 3, half-maximal inhibitory concentration: 155000 nM
Estimate against measurement, compound 3: 17-fold (1.24 log units) below; measured number above the stated range.
By their numbers in this assay, from the lowest: compound 2; then compounds 3 and 1 (each within the scatter of the next).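

In this assay, within the data shown here, the aromatic carbon between two ring nitrogen atoms proves sensitive to its substituent: with the azido side chain held constant, chloro in place of fluoro gives a 50-fold higher number from compound 2 to compound 3 (1.70 log units; beyond the scatter), the first reading that isolates this exchange. With chloro held constant, azido in place of methylsulfonyl on the saturated chain carbon gives a 1.0-fold lower number from compound 1 to compound 3 (0.00 log units; within the scatter), so this pair shows no separation between the two side chains. Nothing available accounts for either step.

On these data alone, the reading for the side chain comes from chloro compounds alone, so it remains open whether azido and methylsulfonyl would also stay within the scatter of each other with fluoro on the ring, or whether the fluoro and chloro step holds with a side chain such as an amine or a carboxylic acid. As far as these compounds go, the shape of the trend at the ring position also remains open, as hydrogen, bromo, methyl and amino groups there would show whether fluoro stands apart or belongs to a graded series.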